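Swapping a methoxy for a fluorine on the amide's aryl ring

The source may hold more compounds than are shown below. What is called first, only, known or untested is meant among the compounds shown, and "the series" means these compounds.

Measured so far:
compound 1 `COc1ccc(C(=O)NCc2ccc(CNS(=O)(=O)c3ccccc3)cc2)cc1`, 1000 nM
compound 2 `O=C(NCc1ccc(CNS(=O)(=O)c2ccccc2)cc1)c1cccnc1`, 10 nM
compound 3 `COc1ccccc1C(=O)NCc1ccc(CNS(=O)(=O)c2ccccc2)cc1`, 1 nM

All three compounds share one core and differ only in the aryl group attached to the carbonyl. In an assay on MDA-MB-231 cells for binding affinity to C-X-C chemokine receptor type 4 (Homo sapiens), read by immunofluorescence and microscopy, with stated times of 10 min and 30 min (a lower number here means that less compound is needed, a higher number that more compound is needed for the effect), compound 3 gives 1 nM, the lowest of the three numbers. Its nearest neighbour is compound 2, with a 10-fold lower number from compound 2 to compound 3 (1.00 log units; beyond the scatter), and the furthest is compound 1, with a 1000-fold lower number from compound 1 to compound 3 (3.00 log units; beyond the scatter). Both steps show that the aryl group on the carbonyl sets the number strongly.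

Compound 4 `O=C(NCc1ccc(CNS(=O)(=O)c2ccccc2)cc1)c1ccccc1F` keeps that aryl ring but changes its substituent: fluoro in place of methoxy on an aromatic carbon. For the measured compounds named here, no measured step swaps a methoxy for a fluoro, so the two steps above only say that this part of the molecule is sensitive; they do not tell the direction. Since compound 3 gives the lowest number with the methoxy in this position, and the change keeps the ring and the position of the group, a modest rise in this assay is expected rather than a large one. For compound 4 the estimate is 5 nM, within 1 nM to 30 nM. This expected step is a 5.0-fold higher number from compound 3 to compound 4 (0.70 log units; beyond the scatter).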

Compound 4, effective concentration (reported as EC, without a stated level of effect): 1000 nM
For compound 4 the middle estimate is 200-fold (2.30 log units) below the measured one; the whole stated range lies below it.
By their numbers in this assay, from the lowest: compound 3; then compound 2; then compounds 1 and 4 (each within the scatter of the next).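

In this assay the step is a 1000-fold higher number from compound 3 to compound 4 (3.00 log units; beyond the scatter), which shows that the group on this aromatic carbon matters as much as the choice of aryl ring: the ring and the place stay the same, and a single small substituent swap still moves the number strongly. The comparison with the other compounds points the same way, with a 100-fold higher number from compound 2 to compound 4 (2.00 log units; beyond the scatter) and no change at the digits printed from compound 1 to compound 4 (within the scatter), so having some group ortho to a large group is not enough to give the low number of compound 3; in this small set that low number appears only with methoxy in that place. The data shown offer no measurement that explains this jump.

The compounds shown leave open whether the oxygen of the methoxy is what counts, which a hydroxyl, an ethoxy or an amine in the same place would help to separate. They also leave open whether the gap between methoxy and fluoro holds when the rest of the shared core changes, for example with a methyl or a chlorine on the benzenesulfonamide ring.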